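The compounds below may be only part of what the source reports. "The series", "measured", "known", "first", "only" and "open" are said of these compounds alone.

Among the compounds with values here, compound 3 `Nc1ccc(S(=O)(=O)N2CCN(c3ncc(C(O)(C(F)(F)F)C(F)(F)F)cc3-c3ccncc3)CC2)cn1` gives 31 mL.min-1.g-1 in an ADME assay (liver) for metabolic stability, with Liver microsome (Rattus norvegicus) as the target, using microsomes and NADPH, with a stated time of 30 min, tested at 1 uM (a lower number here means slower removal, a higher number faster removal of the compound), the lowest of the three numbers so far. Compound 1 `Nc1ccc(S(=O)(=O)N2CCN(c3ncc(C(O)(C(F)(F)F)C(F)(F)F)cc3C#CC3CC3)CC2)cn1` gives 67 mL.min-1.g-1 and compound 2 `CS(=O)(=O)Nc1cccc(-c2cc(C(O)(C(F)(F)F)C(F)(F)F)cnc2N2CCN(S(=O)(=O)c3ccc(N)nc3)CC2)c1` gives 81 mL.min-1.g-1; the steps of a 2.2-fold lower number from compound 1 to compound 3 (0.33 log units; beyond the scatter) and a 2.6-fold lower number from compound 2 to compound 3 (0.42 log units; beyond the scatter) place compound 3 modestly below both. Compound 4 `Nc1ccc(S(=O)(=O)N2CCN(c3ncc(C(O)(C(F)(F)F)C(F)(F)F)cc3-c3ccc4c(c3)CC(=O)N4)CC2)cn1` differs from compound 3 by a group of 10 heavy atoms (8 carbon, 1 nitrogen, 1 oxygen; one five-membered non-aromatic ring with 1 hetero atom, one six-membered aromatic ring of carbon only) in place of a group of 6 heavy atoms (5 carbon, 1 nitrogen; one six-membered aromatic ring with 1 hetero atom), on an aromatic carbon. Both measured steps bear on this change, since each swaps the group on that aromatic carbon, and each was a modest step. The entering group, like that of compound 2 rather than compound 1, is built on a six-membered aromatic ring of carbon only, so a modest rise is expected, a 2.1-fold higher number from compound 3 to compound 4 (0.32 log units; beyond the scatter). Compound 4 is accordingly estimated at 65 mL.min-1.g-1, with a range from 30 mL.min-1.g-1 to 140 mL.min-1.g-1.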

Compound 4, intrinsic clearance in microsomes: 119 mL.min-1.g-1
Compound 4: middle estimate off by 1.8-fold (0.26 log units), on the low side; low and high end bracket the measured number.
By their numbers in this assay, from the lowest: compound 3; then compounds 1, 2 and 4 (each within the scatter of the next).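

In this assay, within the data shown here, pyridin-4-yl now stands apart at this aromatic carbon, with a 3.8-fold higher number from compound 3 to compound 4 (0.58 log units; beyond the scatter) as the largest step so far. The entering group, despite its five-membered non-aromatic ring and hydrogen-bond donor, is not separated from the groups of the other two compounds: a 1.5-fold higher number from compound 2 to compound 4 (0.17 log units; within the scatter) and a 1.8-fold higher number from compound 1 to compound 4 (0.25 log units; within the scatter). No measurement shown accounts for this result.

Open, on these data alone, is whether the ring nitrogen of pyridin-4-yl accounts for the low number of compound 3; a plain phenyl or pyridin-3-yl on this aromatic carbon would bear on that.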